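Swapping the aryl group on a cytotoxic ring scaffold

A few compounds are considered here, and "the series" means these few. Any claim that something is new, unique, unknown or untested is made for them only; others in the source may bear on it.

Measured in a functional assay on A549 cells (Homo sapiens) for cytotoxicity, read by MTT assay; a lower number here means a stronger inhibitor, a higher number a weaker inhibitor:
- Compound 1 `N#Cc1c(-c2ccc(F)cc2)cc(-c2c(O)c3ccccc3oc2=O)nc1N`: 22300 nM
- Compound 2 `O=c1oc2ccccc2c(O)c1-c1cc(-c2c(F)cccc2Cl)nc(S)n1`: 3980 nM
- Compound 3 `COc1cccc(C2CC(c3c(O)c4ccccc4oc3=O)=NN2)c1`: 5910 nM

Compound 3, at 5910 nM, lies within the scatter of compound 2, at 3980 nM. Compound 1, at 22300 nM, carries a higher number than compound 3, and that gap lies beyond the scatter.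

Compound 4 `O=c1oc2ccccc2c(O)c1C1=NNC(c2ccc(F)cc2)C1` has not yet been measured. It carries 4-fluorophenyl in place of 3-methoxyphenyl on a saturated ring carbon. The rest of the structure of compound 3 stays as it is. Among the compounds with values here, no two measured compounds differ in one place, so the data hold no direct measure of such a swap. The estimate therefore starts from compound 3 at 5910 nM, and no shift beyond the scatter is expected in this assay. The expected step is a 1.0-fold higher number from compound 3 to compound 4 (0.01 log units; within the scatter). For compound 4 the estimated value is 6000 nM, with an expected range of 2200 nM to 17000 nM.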

Compound 4, half-maximal inhibitory concentration: 1050 nM
Compound 4: the middle estimate sits 5.7-fold (0.76 log units) above what was measured; measured number outside the range, below it.
By their numbers in this assay, from the lowest: compound 4; then compounds 2 and 3 (each within the scatter of the next); then compound 1.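

In this assay, the aryl group on this saturated ring carbon proves to matter: 4-fluorophenyl in place of 3-methoxyphenyl gives a 5.6-fold lower number from compound 3 to compound 4 (0.75 log units; beyond the scatter) in this one pair. Within the data shown here, the earlier compounds included no pair differing in one place, so this is the first direct reading of a single swap, and it shows that this position can respond to a change of aryl group beyond the scatter. Nothing measured alongside these numbers bears on why the swap has this effect.

A single swap cannot say whether the step follows the loss of the methoxy group or the arrival of fluorine, and a plain phenyl group would help separate the two. The compounds shown also leave open how this position would respond to an aryl group carrying an amine or a carboxylic acid.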